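The source may hold more compounds than are shown below. What is called first, only, known or untested is meant among the compounds shown, and "the series" means these compounds.

Compounds measured:
compound 1 `Cc1nc(N)sc1CCCN/C(N)=N/C(=O)N[C@@H](C)c1ccccc1` gives 0.46
compound 2 `CCCCCCNC(=O)/N=C(\N)NC1CCc2nc(N)sc2C1` gives "not determined" (no result reported)

Among the measured compounds shown here, compound 1 is the only compound here with a number in a functional assay on HEK293T cells for agonist activity at histamine H2 receptor (Homo sapiens), read by beta-arrestin recruitment; on this read-out higher numbers stand for larger maximal responses and lower numbers for smaller maximal responses. Compound 2 carries no result in this assay, so compound 1 stands alone and cannot be placed above or below any neighbour; its maximal response falls short of that of the reference agonist.

Compound 3 `Cc1nc(N)sc1CCCN/C(N)=N/C(=O)NC(C)c1ccco1` has not been measured in this assay. It differs from compound 1 in one place: 1-(furan-2-yl)ethyl in place of 1-phenylethyl on an amide-type nitrogen. For the measured compounds named here, no step between measured compounds is available to show how such a change affects the maximal response, so any expectation rests on the single value of compound 1 and on the modest size of the change.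

For compound 3 the step a number 0.040 lower from compound 1 to compound 3 (within the scatter) is expected to be small, most likely within the usual scatter and, if anything, slightly downward. On that basis compound 3 is estimated to give 0.42 in this assay, with a plausible range from 0.25 to 0.6.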

Compound 3, intrinsic activity: the largest response reached, as a fraction of the reference agonist's: 0.25
Estimate against measurement, compound 3: 0.17 above, within the range that was stated.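

In this assay, the group on the amide-type nitrogen proves to matter for the maximal response: 1-(furan-2-yl)ethyl in place of 1-phenylethyl gives a number 0.21 lower from compound 1 to compound 3 (beyond the scatter) and this places the exchange outside what repeated measurements alone would produce. Among the compounds shown here, compound 1 had stood alone until now, so this is the first sign that a five-membered aromatic ring with one hetero atom does not simply stand in for the six-membered aromatic ring of carbon at this place, although the step is a single one and shows no general pattern. No supporting measurement accompanies the result, so the step stays without an explanation.

For the compounds shown here, the exchange also carries a second difference, as compound 1 has a defined stereocentre in this group while compound 3 has none, and the single step cannot separate the ring from the stereochemistry. The compounds shown also leave open how a 1-(thiophen-2-yl)ethyl group or a plain benzyl group on this nitrogen would compare with 1-phenylethyl, and whether either would hold the response of compound 1.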